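Changing the Outer Group on a Shared Core

The compounds below may be only part of what the source reports. "The series", "measured", "known", "first", "only" and "open" are said of these compounds alone.

Of the compounds shown here, three sharing one core have been tested in an assay on isolated protein for agonist activity at Bile acid receptor (Homo sapiens), read by AlphaScreen, with a stated time of 30 min; a lower number here means that less compound is needed, a higher number that more compound is needed for the effect. Compound 1 `COC(=O)c1cccc(-c2ccc([C@H]3S[C@@H](C)C(=O)Nc4c3c(C)nn4-c3ccccc3C)cc2)c1` gives "not active" (no number reported) in this assay. Compound 2 `Cc1ccccc1-n1nc(C)c2c1NC(=O)[C@H](C)S[C@@H]2c1ccc(-c2ccsc2)cc1` gives 1400 nM in this assay. Compound 3 `Cc1ccccc1-n1nc(C)c2c1NC(=O)[C@H](C)S[C@@H]2c1ccc(OCc2ccccc2)cc1` gives "not active" (no number reported) in this assay, so no single number is available for it, and the same is true of compound 1; only compound 2 has a measured concentration in this set.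

The next compound, compound 4 `COC(=O)c1ccc(-c2ccc([C@H]3S[C@@H](C)C(=O)Nc4c3c(C)nn4-c3ccccc3C)cc2)cc1`, differs from compound 3 in one place: 4-(methoxycarbonyl)phenyl in place of benzyloxy on an aromatic carbon. Compound 1 carries the same methoxycarbonylphenyl group attached at a different position and was not active, while the thiophenyl group of compound 2 did give a measurable number. With no measured step of this kind in the series, the direction and size of the change are uncertain; a move from no reported activity to a weak measurable value is possible, as is a further report of no activity. Compound 4 is expected to give about 4000 nM in this assay, within a range from 1000 nM to 20000 nM.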

Compound 4, half-maximal effective concentration: "not active" (no number reported)
For compound 4 the study gives words and no number, and the estimate cannot be compared.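

For the compounds shown here, compound 3 gives "not active" (no number reported) and compound 4 gives "not active" (no number reported), so no step with a size can be read between them. The compounds shown leave open how far the outer group can change while still giving a measurable concentration. No supporting measurement bears on this result.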